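Ketone aryl change from methoxyphenyl to biphenyl

This account rests on a few compounds, and the source may have more. Where it says the series, first, only, none or still open, it means among the compounds named here.

Going by the values given here, in a functional assay on A549 cells (Homo sapiens) for cytotoxicity, read by MTT assay, with a stated time of 48 h (a higher number here means a weaker inhibitor, a lower number a stronger inhibitor), compound 1 `COc1cc(-c2nnc3n2NC(c2ccco2)C(C(=O)c2ccc(F)cc2)S3)cc(OC)c1OC` gives 53700 nM, the only actual number in the set. Compound 2 `COc1cc(-c2nnc3n2NC(c2ccco2)C(C(=O)C2CC2)S3)cc(OC)c1OC` returns only a limit of this assay, > 100000 nM. Compound 3 `COc1ccc(C(=O)C2Sc3nnc(-c4cc(OC)c(OC)c(OC)c4)n3NC2c2ccco2)cc1` likewise stands only at a limit, > 100000 nM, with no number of its own. The steps of an at least 1.8-fold higher number from compound 1 to compound 2 (0.27 log units; that floor lies within the scatter) and an at least 1.8-fold higher number from compound 1 to compound 3 (0.27 log units; that floor lies within the scatter) are floors only, and a step that the two limits leave unreadable from compound 2 to compound 3 cannot be read, because of the limit of > 100000 nM in this assay, at which 2 of the 3 values shown sit. Compound 4 `COc1cc(-c2nnc3n2NC(c2ccco2)C(C(=O)c2ccc(-c4ccccc4)cc2)S3)cc(OC)c1OC` differs from compound 3 by phenyl in place of methoxy on an aromatic carbon. Among the compounds with values here, no measured step exchanges methoxy for phenyl, so none bears directly on this change; all three measured values sit at or near the limit. Compound 4 is therefore expected near 80000 nM, within 30000 nM to 300000 nM. The expected step is an at least 1.2-fold lower number from compound 3 to compound 4 (0.09 log units; that floor lies within the scatter), meaning nothing beyond the scatter.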

Compound 4, half-maximal inhibitory concentration: > 100000 nM
Compound 4 ended at the assay's limit; the forecaster's own chance of this, stated with the estimate: 60%; middle value at least 1.2-fold (0.09 log units) from the limit.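

Compound 4, with 4-phenylphenyl on the carbonyl carbon, stands at the assay's limit like compound 2 and compound 3, so among the compounds shown only the 4-fluorophenyl of compound 1 gives an actual number in this assay. Going by these compounds alone, the one readable step is a floor: an at least 1.8-fold higher number from compound 1 to compound 4 (0.27 log units; that floor lies within the scatter). The steps to compound 4 from compound 2 and from compound 3 cannot be read: the limit of > 100000 nM in this assay, at which 3 of the 4 values shown sit.

As far as these compounds go, the true distance between compound 1 and the other three stays open. So does whether an amine at this same aromatic carbon would give a number inside the assay's range.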